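The source may hold more compounds than are shown below. What is called first, only, known or untested is meant among the compounds shown, and "the series" means these compounds.

Measured compounds: compound 1 `CCOC(=O)Cn1cc(CNC(=O)c2cn(Cc3ccccc3)nn2)nn1` gives 35000 nM; compound 2 `CC(=O)OCCn1cc(CNC(=O)c2cn(Cc3ccccc3)nn2)nn1` gives 28000 nM; compound 3 `CCOC(=O)Cn1cc(-c2cccc(NC(=O)c3cn(Cc4ccccc4)nn3)c2)nn1` gives 21000 nM, all in a functional assay on B16 cells (Mus musculus) for cytotoxicity, read by MTT assay, with a stated time of 48 h; on this read-out lower numbers stand for stronger inhibition and higher numbers for weaker inhibition.

Compound 1 and compound 2 share a core and differ only by acetoxymethyl in place of ethoxycarbonyl on a saturated chain carbon bound to an aromatic nitrogen; the step of a 1.3-fold lower number from compound 1 to compound 2 (0.10 log units; within the scatter) is small. Compound 3 rests on a different core, and the difference between the two cores is not broken down here. Compound 4 `CC(=O)OCCn1cc(-c2cccc(NC(=O)c3cn(Cc4ccccc4)nn3)c2)nn1` has not yet been measured in this assay; it differs from compound 3 by acetoxymethyl in place of ethoxycarbonyl on a saturated chain carbon bound to an aromatic nitrogen, the same change that was made from compound 1 to compound 2. Since that earlier step stayed within the scatter, compound 4 is expected to lie close to compound 3, with a step of about a 1.2-fold lower number from compound 3 to compound 4 (0.09 log units; within the scatter). Compound 4 is therefore estimated at 17000 nM, between 8000 nM and 40000 nM.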

Compound 4, half-maximal inhibitory concentration: 25100 nM
Compound 4: middle estimate off by 1.5-fold (0.17 log units), on the low side, and the stated range covers the measured number.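

In this assay, putting acetoxymethyl in place of ethoxycarbonyl on the core of compound 3 gives a 1.2-fold higher number from compound 3 to compound 4 (0.08 log units; within the scatter), so the number stays in place, as it did on the core of compound 1. The two steps agree within their scatter: the same change on two cores in this assay, a 1.3-fold lower number (0.10 log units; within the scatter) from compound 1 to compound 2 and a 1.2-fold higher number (0.08 log units; within the scatter) from compound 3 to compound 4, 1.5-fold (0.17 log units) apart, within the scatter of two such steps. This shows that on these two cores the change carries over as a step too small to read, but it gives the change no direction and does not show that it would stay this small on any other core.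

The compounds shown leave open what a carboxylic acid or an amine would do in place of either group on that saturated chain carbon. They also leave open whether a longer chain there would behave alike.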